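Ester chain extension on the shared core

A few compounds are considered here, and "the series" means these few. Any claim that something is new, unique, unknown or untested is made for them only; others in the source may bear on it.

Compound 1 `CCCCCOC(=O)CCC(=O)N1CCN(CCCOc2cc3c(Nc4ccc(F)c(Cl)c4)ncnc3cc2OC)CC1`: 18.2%
Compound 2 `CCCCCCCCCCOC(=O)CCC(=O)N1CCN(CCCOc2cc3c(Nc4ccc(F)c(Cl)c4)ncnc3cc2OC)CC1`: 2%
Compound 3 `CCCCCCCCCCCCOC(=O)CCC(=O)N1CCN(CCCOc2cc3c(Nc4ccc(F)c(Cl)c4)ncnc3cc2OC)CC1`: 2.3%

All numbers come from a functional assay on A549 cells (Homo sapiens) for cytotoxicity, read by MTT assay, with a stated time of 24 h, tested at 80 uM; on this read-out higher numbers stand for a weaker effect at the one concentration tested and lower numbers for a stronger effect. Compound 3 gives the second highest of the three numbers; the nearest is described by a number 0.3 percentage points higher from compound 2 to compound 3 (within the scatter), the furthest by a number 15.9 percentage points lower from compound 1 to compound 3 (beyond the scatter). Compound 4 `CCCCCCCCCCCCCCCCCOC(=O)CCC(=O)N1CCN(CCCOc2cc3c(Nc4ccc(F)c(Cl)c4)ncnc3cc2OC)CC1` differs from compound 3 in one place: pentyl in place of hydrogen on a saturated chain carbon, ten or more bonds along the chain from an oxygen next to a carbonyl group. Among the compounds with values here, the two steps from the shortest ester, a number 16.2 percentage points lower from compound 1 to compound 2 (beyond the scatter) and a number 15.9 percentage points lower from compound 1 to compound 3 (beyond the scatter), were modest lowerings, but the only step at the same place along the chain, a number 0.3 percentage points higher from compound 2 to compound 3 (within the scatter), stayed within the scatter. For this assay no step beyond the scatter is therefore expected. Compound 4 is estimated at 3%, with a range from 0% to 12%. This means an expected a number 0.7 percentage points higher from compound 3 to compound 4 (within the scatter).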

Compound 4, a percentage reported as activity, at one concentration (the size of the read-out at that concentration, not a potency): 83.2%
For compound 4 the middle estimate is 80.2 percentage points below the measured one; measured number above the stated range.
By their numbers in this assay, from the lowest: compounds 2 and 3 (each within the scatter of the next); then compound 1; then compound 4.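

In this assay the ester chain does not level off at its long end: the series shows a number 80.9 percentage points higher from compound 3 to compound 4 (beyond the scatter), together with a number 81.2 percentage points higher from compound 2 to compound 4 (beyond the scatter) and a number 65 percentage points higher from compound 1 to compound 4 (beyond the scatter). Lengthening the chain therefore does not give a step of fixed direction at this position: the same change on two cores in this assay, a number 16.2 percentage points lower (beyond the scatter) from compound 1 to compound 2 and a number 80.9 percentage points higher (beyond the scatter) from compound 3 to compound 4, 97.1 percentage points apart, beyond the scatter of two such steps The second matched pair of chains shows the same reversal: the same change on two cores in this assay, a number 15.9 percentage points lower (beyond the scatter) from compound 1 to compound 3 and a number 81.2 percentage points higher (beyond the scatter) from compound 2 to compound 4, 97.1 percentage points apart, beyond the scatter of two such steps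

Still open, going by these compounds, is where between compound 3 and compound 4 the number turns upward. Also open, on these data alone, is whether a longer chain, or a carboxylic acid at the chain end, would keep it high.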